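Chloro on the Anilide Ring: Compound 3 to Compound 4

The compounds below may be only part of what the source reports. "The series", "measured", "known", "first", "only" and "open" are said of these compounds alone.

Three compounds share one core and differ only in the group on the amide nitrogen. In an assay on cells for displacement of a labelled ligand from Neuronal acetylcholine receptor; alpha3/beta4 (Homo sapiens) (a lower number here means a stronger inhibitor, a higher number a weaker inhibitor), compound 1 `O=C(Nc1ccc(I)cc1)c1cncc(N2CC3CC(C2)N3)c1` gives 103 nM, compound 2 `O=C(Nc1ccc(F)cc1F)c1cncc(N2CC3CC(C2)N3)c1` gives 50 nM, and compound 3 `O=C(Nc1ccccc1)c1cncc(N2CC3CC(C2)N3)c1` gives 192 nM. Compound 3 stands at the highest number of the three; its nearest neighbour is compound 1, while a 3.8-fold higher number from compound 2 to compound 3 (0.58 log units; beyond the scatter) lies beyond the scatter.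

Compound 4 `O=C(Nc1cccc(Cl)c1)c1cncc(N2CC3CC(C2)N3)c1` is obtained from compound 3 by chloro in place of hydrogen on an aromatic carbon. For the measured compounds named here, two measured steps bear on this change, both adding a halogen to the same ring: a 1.9-fold higher number from compound 1 to compound 3 (0.27 log units; within the scatter), and a 3.8-fold higher number from compound 2 to compound 3 (0.58 log units; beyond the scatter). Neither is a chloro at this place, so the guide is loose, but both point the same way, towards a lower number when a halogen is present.

For compound 4 a modest step is therefore expected, a 1.7-fold lower number from compound 3 to compound 4 (0.24 log units; within the scatter), and its estimated value in this assay is 110 nM, within a range of 50 nM to 250 nM.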

Compound 4, inhibition constant: 59 nM
Compound 4: the middle estimate sits 1.9-fold (0.27 log units) above what was measured; low and high end bracket the measured number.
By their numbers in this assay, from the lowest: compounds 2, 4, 1 and 3 (each within the scatter of the next, the first and the last beyond it).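

In this assay the step of a 3.3-fold lower number from compound 3 to compound 4 (0.51 log units; beyond the scatter) shows that one chloro, meta to a large group, moves the number beyond the scatter, whereas the earlier single-halogen step a 1.9-fold higher number from compound 1 to compound 3 (0.27 log units; within the scatter) stayed within it. The 3-chlorophenyl group also brings compound 4 level with the two other halogenated compounds, as the step of a 1.2-fold higher number from compound 2 to compound 4 (0.07 log units; within the scatter) and the step of a 1.7-fold lower number from compound 1 to compound 4 (0.24 log units; within the scatter) both show. No measurement shown here accounts for this effect of the chloro.

On these data alone, it remains open whether a fluoro, a bromo, a methyl or a methoxy at this same place would give a number like that of compound 4. The compounds shown also leave open whether the effect belongs to this place, since 2-chlorophenyl and 4-chlorophenyl are not among them.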